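The source may hold more compounds than are shown below. What is called first, only, known or untested is meant among the compounds shown, and "the series" means these compounds.

Compound 1 `Nc1nc(NCCNc2ncc(-c3ncc[nH]3)c(-c3ccc(F)cc3F)n2)ccc1[N+](=O)[O-]` was studied in an ADME assay on microsomes from liver (Rattus norvegicus) for metabolic stability; on this read-out higher numbers stand for a longer-lived compound and lower numbers for a shorter-lived compound. In this assay compound 1 gives > 0.5 h, which is a limit of the assay rather than a number. Compound 2 `Nc1nc(NCCNc2ncc(-c3ncc[nH]3)c(-c3ccc(F)cc3C(F)(F)F)n2)ccc1[N+](=O)[O-]` likewise gives a limit, > 0.5 h. Compound 3 `Cc1ccc(-c2nc(NCCNc3ccc([N+](=O)[O-])c(N)n3)ncc2-c2ncc[nH]2)c(Br)c1` also gives a limit, > 0.5 h. All three values sit at the limit of > 0.5 h in this assay, at which 3 of the 3 values shown sit, so the structural changes among them, a step that the two limits leave unreadable from compound 1 to compound 2, a step that the two limits leave unreadable from compound 1 to compound 3 and a step that the two limits leave unreadable from compound 2 to compound 3, cannot be sized. Compound 4 `COc1cc(Cl)ccc1-c1nc(NCCNc2ccc([N+](=O)[O-])c(N)n2)ncc1-c1ncc[nH]1` differs from compound 1 in one place: 4-chloro-2-methoxyphenyl in place of 2,4-difluorophenyl on an aromatic carbon. Among the compounds with values here, since none of the measured steps can be read, no direction beyond the scatter is expected here. Compound 4 is expected to sit at the same limit, a step that the limit leaves unreadable from compound 1 to compound 4. The estimate for compound 4 is 1 h, between 0.5 h and 3 h.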

Compound 4, half-life: > 0.5 h
Compound 4 ended at the assay's limit; the forecaster's own chance of this, stated with the estimate: 70%; the middle value lies beyond the limit too.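

Compound 4, like compound 1, compound 2 and compound 3, gives a limit rather than a number in this assay, so none of the steps to compound 4 can be read: the limit of > 0.5 h in this assay, at which 4 of the 4 values shown sit.

From the compounds shown here alone, the actual half-lives of these four compounds, and whether changing the substituted phenyl group on the shared core alters them at all, remain open.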